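Swapping Selenium for an Amino Group on Two Cores

This account rests on a few compounds, and the source may have more. Where it says the series, first, only, none or still open, it means among the compounds named here.

Measured compounds:
- compound 1, `[SeH]c1nc([SeH])c2ccccc2n1`, gives 2920 nM
- compound 3, `[SeH]c1nc([SeH])c2cccnc2n1`, gives 9830 nM
- compound 2, `Nc1nc([SeH])nc2ncccc12`, gives 37300 nM

All three were tested in a functional assay on MCF7 cells (Homo sapiens) for cytotoxicity, read by MTT assay, with a stated time of 72 h; a higher number here means a weaker inhibitor of growth, a lower number a stronger inhibitor of growth. Compound 1 stands lowest of the three; compound 3 sits a step above it, and compound 2 is the highest. Compound 3 and compound 2 share one core and differ in a single place, where a selenium leaves and an amino group enters: one nitrogen atom in place of one selenium atom, on an aromatic carbon. That change made a step of a 3.8-fold higher number from compound 3 to compound 2 (0.58 log units; beyond the scatter), a modest weakening of growth inhibition that lies beyond the usual scatter.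

Compound 4, `Nc1nc([SeH])nc2ccccc12`, has not yet been measured. It relates to compound 1 exactly as compound 2 relates to compound 3: one nitrogen atom in place of one selenium atom, on an aromatic carbon. The words describing where the change sits are the same for both pairs, so this is the same kind of change on a second core. The difference between the core of compound 1 and the core of compound 3 is not broken down here.

Going by the values given here, only one earlier example of this change is available, so the expectation rests on it alone. Compound 4 is expected to show a step of about a 3.8-fold higher number from compound 1 to compound 4 (0.58 log units; beyond the scatter), mirroring the step of a 3.8-fold higher number from compound 3 to compound 2 (0.58 log units; beyond the scatter), because compound 1 starts at 2920 nM and the same kind of swap on compound 3 weakened inhibition. The estimated value for compound 4 is 11000 nM, with a plausible range from 4000 nM to 30000 nM.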

Compound 4, concentration for 50% growth inhibition: 150 nM
The estimate for compound 4 lay 73-fold (1.87 log units) above the measured number, and the stated range ends above it.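

In this assay, putting an amino group in place of one selenium on the core of compound 1 gave a step of a 19-fold lower number from compound 1 to compound 4 (1.29 log units; beyond the scatter), and this step runs the opposite way to the one seen when the same change was made on the other core: the same change on two cores in this assay, a 3.8-fold higher number (0.58 log units; beyond the scatter) from compound 3 to compound 2 and a 19-fold lower number (1.29 log units; beyond the scatter) from compound 1 to compound 4, 74-fold (1.87 log units) apart, beyond the scatter of two such steps. In this series, then, the result of this swap on one core did not predict even the direction of its result on the other, so the core the change sits on matters for the outcome. This rests on just two pairs of compounds, however, and it shows neither which feature of the two cores separates them nor which of the two steps would be more typical of further cores.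

The compounds shown leave open what a methylamino or a hydroxyl group would do in the same place on each core, and whether either would follow the amino group on that core. They also leave open what replacing the remaining selenium would do, and whether a third core would side with compound 4 or with compound 2.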